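A few compounds are considered here, and "the series" means these few. Any claim that something is new, unique, unknown or untested is made for them only; others in the source may bear on it.

Compound 3 `CCCCNc1nc(N)nc2c1CN(Cc1ccco1)CC2` gives 0.08 uM in an assay on HEK293 cells for agonist activity at Toll-like receptor 8 (Homo sapiens), read by a luciferase reporter, with a stated time of 6 h; on this read-out higher numbers stand for an effect only at larger amounts of compound and lower numbers for an effect already at smaller amounts. Among the three measured compounds, compound 1 `CCCCNc1nc(N)nc2c1CN(Cc1cccc(Cl)c1Cl)CC2` gives 0.18 uM and compound 2 `CCCCNc1nc(N)nc2c1CN(Cc1c(Cl)cccc1Cl)CC2` gives 0.14 uM. The step of a 2.3-fold lower number from compound 1 to compound 3 (0.35 log units; beyond the scatter) is beyond the scatter, whereas a 1.8-fold lower number from compound 2 to compound 3 (0.24 log units; within the scatter) and a 1.3-fold lower number from compound 1 to compound 2 (0.11 log units; within the scatter) are within it, so compound 3 cannot be set apart from compound 2 on these numbers.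

Compound 4 `CCCCNc1nc(N)nc2c1CN(C(=O)c1cocn1)CC2` differs from compound 3 in one place: (1,3-oxazol-4-yl)carbonyl in place of (furan-2-yl)methyl on an amine nitrogen in a ring. The measured steps all exchange one aromatic group for another on a saturated chain carbon and leave that carbon in place; none of them exchanges the saturated carbon for a carbonyl or brings in a ring with two hetero atoms. Those aromatic swaps moved the numbers from within the scatter to a modest change, so the directly comparable evidence is thin and a wider range is warranted.

Compound 4 is therefore expected to give about 0.5 uM, with a range from 0.1 uM to 3 uM, which would mean an estimated step of a 6.3-fold higher number from compound 3 to compound 4 (0.80 log units; beyond the scatter) in this assay.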

Compound 4, minimum effective concentration: 0.2 uM
Beside the measured number, compound 4's estimate is 2.5-fold (0.40 log units) above it; low and high end bracket the measured number.
By their numbers in this assay, from the lowest: compounds 3, 2, 1 and 4 (each within the scatter of the next, the first and the last beyond it).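

Compound 4 is the first compound shown with a carbonyl rather than a saturated chain carbon on the amine nitrogen in the ring, and the first with a five-membered aromatic ring with 2 hetero atoms at this place. In this assay the exchange gives a 2.5-fold higher number from compound 3 to compound 4 (0.40 log units; beyond the scatter) and is a modest step, so compound 4 still gives a read-out at 0.2 uM with the carbonyl in place. Nothing available bears on the reason for this step.

The step joins two exchanges, the linking carbon and the ring, and the compounds shown cannot apportion it: (furan-2-yl)carbonyl and (1,3-oxazol-4-yl)methyl would separate them. Also open, on these data alone, is how a plain acetyl group or a free ring amine would read at this nitrogen.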